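The compounds below may be only part of what the source reports. "The series", "measured", "known", "first", "only" and "open" are said of these compounds alone.

Working notes on the lactone series in a functional assay on RAW264.7 cells (Mus musculus) for inhibition, read by Griess assay, with stated times of 1 h and 24 h; a lower number here means a stronger inhibitor, a higher number a weaker inhibitor.

Compound 1 `O=C1OC(Cc2nc(-c3ccc(Oc4ccccc4)cc3)no2)c2ccccc21` sits at the limit of this assay: its result is recorded as > 10000 nM, a limit rather than a number, as noted in the limit of > 10000 nM in this assay, at which 1 of the 3 values shown sits. Compound 2 `CCCCOc1ccc(C(O)C2OC(=O)c3c(OC)cc(OC)cc32)cc1` gives 1800 nM, the lowest of the two numbers in hand. Among the measured compounds shown here, compound 3 `CCCCCCOc1ccc(C(O)C2OC(=O)c3c(OC)cc(OC)cc32)cc1` gives 5360 nM; the only single-point step measured runs a 3.0-fold higher number from compound 2 to compound 3 (0.47 log units; beyond the scatter).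

Compound 4 `COc1cc(OC)c2c(c1)C(C(O)c1ccc(OCc3ccc(Cl)cc3)cc1)OC2=O` is not yet measured in this assay. It differs from compound 2 as 4-chlorophenyl in place of propyl on a saturated chain carbon bound to an oxygen on an aromatic ring. For the measured compounds named here, the one measured step that touches the same part of the molecule is the chain growth from compound 2 to compound 3, which went in the weaker direction by a modest amount. Going by the values given here, the change to compound 4 also adds bulk at the same oxygen but exchanges a chain for an aromatic group, and no measured pair shows that kind of exchange, so the expectation is weak. A small shift toward the weaker side is expected, so that the estimate for compound 4 in this assay is 2800 nM, with a range from 700 nM to 9000 nM; the expected step is a 1.6-fold higher number from compound 2 to compound 4 (0.19 log units; within the scatter).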

Compound 4, half-maximal inhibitory concentration: 4320 nM
For compound 4 the middle estimate is 1.5-fold (0.19 log units) below the measured one; the measured number falls inside the stated range.
By their numbers in this assay, from the lowest: compound 2; then compounds 4 and 3 (each within the scatter of the next). At a limit, above all of these: compound 1.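

In this assay, among the compounds shown here, this is the first aromatic group seen at this position: 4-chlorophenyl in place of propyl, on a saturated chain carbon bound to an oxygen on an aromatic ring, gives a 2.4-fold higher number from compound 2 to compound 4 (0.38 log units; beyond the scatter), the same direction as the chain growth. The exchange of pentyl for 4-chlorophenyl at the same place gives a 1.2-fold lower number from compound 3 to compound 4 (0.09 log units; within the scatter), so a plain chain and a ring-bearing group cannot be told apart in this pair. Both replacements of the butoxy group of compound 2 therefore read on the weaker side of it, while the data offer no explanation for either shift.

Left open is whether the chlorine contributes anything, which a plain benzyl group on this oxygen would show, and whether a shorter chain such as ethyl would give a lower number than compound 2 does. Also unsettled is how this position responds to an amine or a carboxylic acid at the end of the chain, since every group shown here carries neither.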